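Halogen Swap on the Aryl Group of a Nucleoside Core

This account rests on a few compounds, and the source may have more. Where it says the series, first, only, none or still open, it means among the compounds named here.

Compound 1, `CCCC#Cc1cc([C@@H]2O[C@H](CO)[C@@H](O)[C@H]2O)n2ncnc(N)c12`, gives 200 nM in a functional assay on HCT-116 cells (Homo sapiens) for antiproliferative activity, with a stated time of 72 h; on this read-out lower numbers stand for stronger inhibition and higher numbers for weaker inhibition.
Compound 2, `Nc1ncnn2c([C@@H]3O[C@H](CO)[C@@H](O)[C@H]3O)cc(-c3ccc(F)cc3)c12`, gives 42500 nM in this assay.
Compound 3, `Nc1ncnn2c([C@@H]3O[C@H](CO)[C@@H](O)[C@H]3O)cc(-c3ccc(Cl)cc3)c12`, gives 59300 nM in this assay.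

Compound 3 has the highest number of the three, far from compound 1 (a 300-fold higher number from compound 1 to compound 3 (2.47 log units; beyond the scatter)), but its gap to the nearest other value is within the scatter (a 1.4-fold higher number from compound 2 to compound 3 (0.14 log units; within the scatter)). Compound 4, `Nc1ncnn2c([C@@H]3O[C@H](CO)[C@@H](O)[C@H]3O)cc(-c3ccc(F)cc3F)c12`, differs from compound 3 by 2,4-difluorophenyl in place of 4-chlorophenyl on an aromatic carbon. Within the data shown here, the only step that bears on this is the halogen exchange from compound 2 to compound 3, which stayed within the scatter, so a change in this assay no larger than the scatter is expected for compound 4 (a 1.2-fold lower number from compound 3 to compound 4 (0.07 log units; within the scatter)). Compound 4 is therefore estimated at 50000 nM, within a range from 20000 nM to 120000 nM.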

Compound 4, half-maximal inhibitory concentration: 59500 nM
Compound 4: the middle estimate sits 1.2-fold (0.08 log units) below what was measured, within the range that was stated.
By their numbers in this assay, from the lowest: compound 1; then compounds 2, 3 and 4 (each within the scatter of the next).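

In this assay, fluoro in place of hydrogen on the aryl ring gives no readable change (a 1.4-fold higher number from compound 2 to compound 4 (0.15 log units; within the scatter)), and neither does the swap between the two halogenated aryl groups (a 1.0-fold higher number from compound 3 to compound 4 (0.00 log units; within the scatter)). Among these three compounds, then, the number and kind of halogens on the aryl ring make no difference beyond the scatter. The 2,4-difluorophenyl group also stays as far from pent-1-yn-1-yl as the other aryl groups do (a 300-fold higher number from compound 1 to compound 4 (2.47 log units; beyond the scatter)).

From the compounds shown here alone, what a saturated pentyl chain or an amine would give on this carbon remains open. No available evidence accounts for the gap between the pent-1-yn-1-yl and aryl compounds.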